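Oxan-4-yl in Place of Pyridin-4-yl: Cytotoxicity Outlook

A few compounds are considered here, and "the series" means these few. Any claim that something is new, unique, unknown or untested is made for them only; others in the source may bear on it.

Compound 1 `COc1nc(-c2ccncc2)ccc1[C@@H](c1ccccc1)[C@@](O)(CCN(C)C)c1cccc2ccccc12`: in a toxicity assay on Vero cells (Chlorocebus sabaeus) for cytotoxicity (on this read-out higher numbers stand for lower toxicity in this test and lower numbers for higher toxicity in this test), compound 1 gives > 50 ug/mL, a limit of the test.
Compound 2 `COc1ncc(-c2ccccc2)cc1[C@@H](c1ccccc1)[C@@](O)(CCN(C)C)c1cccc(F)c1F`: in this assay compound 2 gives > 50 ug/mL, also a limit.
Compound 3 `COc1ncc(-c2ccccc2)cc1[C@@H](c1ccccc1)[C@@](O)(CCN(C)C)c1cccc2ccccc12`: in this assay compound 3 gives > 50 ug/mL, again a limit.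

Compound 1 thus stands only at a limit, and the same holds for the two other measured compounds: the limit of > 50 ug/mL in this assay, at which 3 of the 3 values shown sit. Going by the values given here, the one measured step, a step that the two limits leave unreadable from compound 2 to compound 3, cannot be read because both ends are limits. Among the compounds with values here, no measured step touches the part of the molecule that changes here.

Compound 4 `COc1nc(C2CCOCC2)ccc1[C@@H](c1ccccc1)[C@@](O)(CCN(C)C)c1cccc2ccccc12` is not yet measured. It differs from compound 1 in one place: oxan-4-yl in place of pyridin-4-yl on an aromatic carbon. Since every measured compound sits at the limit, the step from compound 1 to compound 4 is expected to stay hidden behind that same limit, a step that the limit leaves unreadable from compound 1 to compound 4. Compound 4 is therefore expected to give about 60 ug/mL in this assay, with a likely range from 30 ug/mL to 120 ug/mL, most probably reported once more only as a limit.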

Compound 4, half-maximal cytotoxic concentration: > 50 ug/mL
Compound 4 gave a limit, no number; the forecaster's own chance of this, stated with the estimate: 85%; the middle value is on the limit's open side.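

Compound 4 ends at a limit, as compound 1 does, so no size can be read for the change between compound 1 and compound 4: the limit of > 50 ug/mL in this assay, at which 4 of the 4 values shown sit.

The compounds shown leave open what actual number any of them would give in this assay, and whether oxan-4-yl and pyridin-4-yl differ there at all.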